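The source may hold more compounds than are shown below. What is called first, only, known or untested is meant among the compounds shown, and "the series" means these compounds.

Measured so far:
Compound 1, `Cn1c(-c2cc(-c3cccc(F)c3)on2)cc2ccccc21`, was tested in a functional assay on Calu-3 cells (Homo sapiens) for cytotoxicity, read by WST assay, with a stated time of 72 h; a lower number here means a stronger inhibitor, a higher number a weaker inhibitor; the value for compound 1 is a limit of the assay, not a number: > 100000 nM.
Compound 2, `COc1cccc(-c2cc(-c3cc4cc(OC)ccc4[nH]3)no2)c1`, was tested in this assay as well; the value for compound 2 is likewise a limit, not a number: > 100000 nM.

Compound 2 therefore stands nowhere in particular among the numbers shown: both values sit at the limit of > 100000 nM in this assay, at which 2 of the 2 values shown sit, so neither compound can be ranked against the other, and no step between measured compounds can be computed.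

Compound 3, `COc1ccc2[nH]c(-c3cc(-c4cccc(F)c4)on3)cc2c1`, differs from compound 2 in one place: fluoro in place of methoxy on an aromatic carbon. Among the measured compounds shown here, with no measured step to rest on, the expectation for compound 3 is a step from compound 2 of a step that the limit leaves unreadable from compound 2 to compound 3, that is, none beyond the scatter. The estimate for compound 3 in this assay is 150000 nM, with a range from 50000 nM to 500000 nM, and most likely the assay again reports only a limit.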

Compound 3, half-maximal inhibitory concentration: > 100000 nM
Compound 3 was reported as a limit (the forecaster's own chance of this, stated with the estimate: 80%); the middle value is on the limit's open side.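

No step can be read from compound 2 to compound 3, because both values are limits and not numbers: the limit of > 100000 nM in this assay, at which 3 of the 3 values shown sit. The compounds shown leave open whether fluoro in place of methoxy changes the value at all, and how compound 1, compound 2 and compound 3 rank.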